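Toward the Morpholinyl Sulfonyl Compound 4

A few compounds are considered here, and "the series" means these few. Any claim that something is new, unique, unknown or untested is made for them only; others in the source may bear on it.

Compound 1 `C#CCN(Cc1ccc2nc(C)nc(O)c2c1)c1ccccc1`: > 10700 nM (a limit)
Compound 2 `C#CCN(Cc1ccc2nc(C)nc(O)c2c1)c1ccc(C(=O)c2ccccc2)cc1`: 6200 nM
Compound 3 `C#CCN(Cc1ccc2nc(C)nc(O)c2c1)c1ccc(S(N)(=O)=O)cc1`: > 26000 nM (a limit)

In a functional assay on GC3/MTK- cells (Homo sapiens) for inhibition (a higher number here means a weaker inhibitor, a lower number a stronger inhibitor), compound 3 has only a limit, > 26000 nM, and no number. Compound 1 likewise has only a limit, > 10700 nM.

Compound 4 `C#CCN(Cc1ccc2nc(C)nc(O)c2c1)c1ccc(S(=O)(=O)N2CCOCC2)cc1` differs from compound 3 in one place: morpholin-4-yl in place of amino on a sulfonyl sulfur. Morpholin-4-yl stands in place of amino on a sulfonyl sulfur.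

Going by the values given here, no measured step makes this exact change, so the evidence is indirect. Benzoyl in place of hydrogen gave an at least 1.7-fold lower number from compound 1 to compound 2 (0.23 log units; that floor lies within the scatter). Sulfamoyl in place of benzoyl gave an at least 4.1-fold higher number from compound 2 to compound 3 (0.62 log units; beyond the scatter). Sulfamoyl in place of hydrogen gave a step that the two limits leave unreadable from compound 1 to compound 3.

Among the compounds with values here, the only number belongs to compound 2, at 6200 nM, so a modest move toward that value is expected, with low confidence. The estimated step is an at least 1.8-fold lower number from compound 3 to compound 4 (0.26 log units; that floor lies within the scatter). For compound 4 the estimated value is 14000 nM, with an expected range of 5000 nM to 40000 nM.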

Compound 4, half-maximal inhibitory concentration: 5200 nM
The estimate for compound 4 lay 2.7-fold (0.43 log units) above the measured number; the measured number falls inside the stated range.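

In this assay, the sulfonyl group on the aromatic carbon does not by itself leave the compound weak, since morpholin-4-yl in place of amino on the sulfonyl sulfur gives an at least 5.0-fold lower number from compound 3 to compound 4 (0.69 log units; beyond the scatter), a floor set by the limit of compound 3: the limit of > 26000 nM in this assay, at which 1 of the 4 values shown sits. The (morpholin-4-yl)sulfonyl group and benzoyl cannot be told apart here, with a 1.2-fold lower number from compound 2 to compound 4 (0.08 log units; within the scatter). Set against hydrogen, the (morpholin-4-yl)sulfonyl group gives an at least 2.0-fold lower number from compound 1 to compound 4 (0.31 log units; beyond the scatter), again a floor, set by the limit of compound 1: the limit of > 10700 nM in this assay, at which 1 of the 4 values shown sits.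

The compounds shown leave open whether the oxygen of the morpholin-4-yl ring matters, which piperidin-1-yl on the sulfonyl sulfur would test. They also leave open whether a ring is needed at all, which a dimethylamino group on the same sulfur would show.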